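The source may report more compounds than this note shows. Statements on the series, on what has been measured and on what is new or still open speak of the compounds shown alone.

Compound 1 `Cc1[nH]c(=O)n(C2CCCCC2)c1-c1ccc(OC(C)C)cc1`: 13000 nM
Compound 2 `CCCCCCCCOc1ccc(-c2c(C)[nH]c(=O)n2C2CCCCC2)cc1`: 8500 nM

In a functional assay on brain (Rattus norvegicus, strain Wistar) for inhibition (on this read-out lower numbers stand for stronger inhibition and higher numbers for weaker inhibition), compound 2 gives 8500 nM. This places it level with compound 1 within the usual scatter of repeated measurements, so the two cannot be ranked. The next compound, compound 3 `Cc1[nH]c(=O)n(C2CCCCC2)c1-c1ccc(Oc2ccccc2)cc1`, keeps the shared core and differs from compound 2 at one place: phenyl in place of octyl on an oxygen on an aromatic ring.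

Among the compounds with values here, only one measured step bears on this change, since it is the only one made at that same place: a 1.5-fold lower number from compound 1 to compound 2 (0.18 log units; within the scatter). Exchanging isopropyl for octyl therefore moved the number by no more than the scatter. From the compounds shown here alone, this is thin evidence, resting on two compounds, and neither carries a ring on that oxygen, so phenyl remains untested there. No step beyond the scatter is expected, although the range has to stay wide. The estimated step is a 1.1-fold higher number from compound 2 to compound 3 (0.02 log units; within the scatter). For compound 3 the expected value is 9000 nM, with an estimated range of 3500 nM to 25000 nM.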

Compound 3, half-maximal inhibitory concentration: 7900 nM
Compound 3: the middle estimate sits 1.1-fold (0.06 log units) above what was measured; the range from low to high includes it.
By their numbers in this assay, from the lowest: compounds 3, 2 and 1 (each within the scatter of the next).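

An aromatic ring on this oxygen now joins the two open chains. In this assay, phenyl in place of octyl gives (a 1.1-fold lower number from compound 2 to compound 3 (0.03 log units; within the scatter)), and phenyl in place of isopropyl gives (a 1.6-fold lower number from compound 1 to compound 3 (0.22 log units; within the scatter)). Octyl has 8 carbon atoms and no ring, phenyl has 6 carbon atoms in one six-membered aromatic ring, and isopropyl is a different chain again, yet compounds 1, 2 and 3 cannot be ranked, so in this set, swapping a chain for a ring on the oxygen shows no measurable effect on the number. Nothing available accounts for why these three groups read alike.

Octyl and phenyl carry no hydrogen-bond donors or acceptors and no net charge, so it stays open whether an amine or a carboxylic acid attached through this oxygen would shift the number beyond the scatter. From the compounds shown here alone, all three compounds also share the same core, so what a change elsewhere on that core would do remains unknown, and it is possible that the real sensitivity of this series lies there rather than on the oxygen.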